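From propyl to 2H-tetrazol-5-yl on compound 1

The source may hold more compounds than are shown below. What is called first, only, known or untested is meant among the compounds shown, and "the series" means these compounds.

In a functional assay on the whole organism (stomach) with Rattus norvegicus as the target (a higher number here means that more compound is needed for the effect, a lower number that less compound is needed), compound 1 (`CCCc1ccc(C(=O)Nc2cc(C(=O)O)cc(C(=O)O)c2)cc1`) gives 94.2 mg/kg. Compound 2 (`O=C(O)c1ccc(NC(=O)c2ccc(C(=O)O)cc2)cc1`) gives 54.3 mg/kg, which lies within the usual scatter of the number for compound 1. Compound 3 (`O=C(Nc1cccc(-c2nn[nH]n2)c1)c1cccc(-c2nn[nH]n2)c1`) gives 15.8 mg/kg, lower than the number for compound 1 by more than the scatter. Compound 1 therefore shares the high end of this small set with compound 2, so it is among those needing more compound for the effect.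

The next compound is compound 4 (`O=C(O)c1cc(NC(=O)c2ccc(-c3nn[nH]n3)cc2)cc(C(=O)O)c1`), in which 2H-tetrazol-5-yl takes the place of propyl on an aromatic carbon: 2H-tetrazol-5-yl in place of propyl on an aromatic carbon. For the measured compounds named here, no two measured compounds differ in one place only, so this change has no direct precedent. Going by the values given here, the only hint is that compound 3, the one measured compound carrying 2H-tetrazol-5-yl, gives 15.8 mg/kg. That points to a moderate fall in the number, beyond the scatter but with much uncertainty. The expected step is a 2.7-fold lower number from compound 1 to compound 4 (0.43 log units; beyond the scatter). For compound 4 the estimated value is 35 mg/kg, with an expected range of 12 mg/kg to 85 mg/kg.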

Compound 4, dose for 50% inhibition: 8.2 mg/kg
The estimate for compound 4 lay 4.3-fold (0.63 log units) above the measured number; the whole stated range lies above it.
By their numbers in this assay, from the lowest: compounds 4 and 3 (each within the scatter of the next); then compounds 2 and 1 (each within the scatter of the next).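

For the compounds shown here, the first direct comparison in this set shows that this position on the core of compound 1 is not indifferent to what it carries. In this assay, 2H-tetrazol-5-yl in place of propyl on the aromatic carbon gives an 11-fold lower number from compound 1 to compound 4 (1.06 log units; beyond the scatter), a large step well beyond the scatter, so far less compound is needed for the effect. The earlier compounds shown here differed from one another in more than one place and could not isolate this change, whereas here a chain without a ring gives way to a five-membered aromatic ring, with the rest of the molecule unchanged.

No measurement available here explains why the number falls so far. From the compounds shown here alone, it also remains open whether the tetrazole is special at this position or whether another group there, such as an amine or a phenyl ring, would give a similar step.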